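From 4-chlorophenyl to 3-chlorophenyl, with little to go on

A few compounds are considered here, and "the series" means these few. Any claim that something is new, unique, unknown or untested is made for them only; others in the source may bear on it.

compound 1 `CCCCCCn1cnc2c(Nc3ccc(Cl)cc3)nc(N[C@H]3CC[C@H](N)CC3)nc21` gives 11700 nM
compound 2 `N[C@H]1CC[C@H](Nc2nc(Nc3ccc(Cl)cc3)c3ncn(C4CCCCC4)c3n2)CC1` gives 9100 nM

In a functional assay on HCC827 cells (Homo sapiens) for inhibition, read by fluorescence, with a stated time of 72 h (a lower number here means a stronger inhibitor of growth, a higher number a weaker inhibitor of growth), compound 1 gives 11700 nM and has only compound 2 to be set against. Going by the values given here, the one measured step is a 1.3-fold lower number from compound 1 to compound 2 (0.11 log units; within the scatter), so these two cannot be told apart. Compound 3 `CCCCCCn1cnc2c(Nc3cccc(Cl)c3)nc(N[C@H]3CC[C@H](N)CC3)nc21` keeps the core of compound 1 and differs by 3-chlorophenyl in place of 4-chlorophenyl on a nitrogen on an aromatic ring. The measured step exchanged hexyl for cyclohexyl and left the chlorophenyl untouched, so no measurement here speaks directly to this change. No step beyond the scatter is expected, and neither direction is favoured: the estimated step is a 1.1-fold lower number from compound 1 to compound 3 (0.03 log units; within the scatter) for now. Compound 3 is expected near 11000 nM in this assay, with an estimated range from 4500 nM to 25000 nM given how little evidence bears on it.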

Compound 3, concentration for 50% growth inhibition: 10200 nM
For compound 3 the middle estimate is 1.1-fold (0.03 log units) above the measured one; low and high end bracket the measured number.
By their numbers in this assay, from the lowest: compounds 2, 3 and 1 (each within the scatter of the next).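

In this assay, the step is a 1.1-fold lower number from compound 1 to compound 3 (0.06 log units; within the scatter), so compound 1 and compound 3 cannot be told apart. Going by these compounds alone, this is the first reading at the chlorophenyl group itself, since the earlier step exchanged only hexyl for cyclohexyl, and it shows that 3-chlorophenyl and 4-chlorophenyl on this nitrogen give numbers within the usual scatter of each other while the rest of the molecule stays fixed. Nothing measured here bears on why these two compounds read alike.

Among the compounds shown, this ring always carries chlorine, so it remains open whether a methoxy group, a trifluoromethyl group or a plain phenyl ring would move the number beyond the scatter. Also open, as far as these compounds go, is whether 3-chlorophenyl would read the same with cyclohexyl in place of hexyl.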